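Replacing methyl by chloro on a shared anticonvulsant core

The source may hold more compounds than are shown below. What is called first, only, known or untested is meant among the compounds shown, and "the series" means these compounds.

Of the compounds shown here, three have been tested in a functional assay on the whole organism (strain Swiss) with Mus musculus as the target, in the maximal electroshock model, with a stated time of 2 h, at a dose of 100 mg/kg by the intraperitoneal route; a lower number here means a weaker effect, a higher number a stronger effect of the compound at the dose given. Compound 1 `CCC(C(=O)N1CCN(c2cccc(C)c2)CC1)N1C(=O)CCC1=O` gives 0%, compound 2 `CCC(C(=O)N1CCN(c2cccc(Cl)c2)CC1)N1C(=O)CCC1=O` gives 0%, and compound 3 `Cc1cccc(N2CCN(C(=O)C(C)N3C(=O)CCC3=O)CC2)c1` gives 0%. Compound 2 differs from compound 1 by chloro in place of methyl on an aromatic carbon, and this step, no change at the digits printed from compound 1 to compound 2 (within the scatter), left the read-out unmoved. Compound 3 differs from compound 1 by hydrogen in place of methyl on a saturated chain carbon, two bonds along the chain from an amide-type nitrogen in a ring and a carbonyl carbon, and that step, no change at the digits printed from compound 1 to compound 3 (within the scatter), was likewise flat.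

Compound 4 `CC(C(=O)N1CCN(c2cccc(Cl)c2)CC1)N1C(=O)CCC1=O` has not yet been measured. It differs from compound 3 by chloro in place of methyl on an aromatic carbon, which is the same change already seen between compound 1 and compound 2, at the same place on the ring. Since that change produced no movement from compound 1 to compound 2, and since compound 3 sits at the same level as both, compound 4 is expected to show a step of about no change at the digits printed from compound 3 to compound 4 (within the scatter) in this assay. The estimated activity of compound 4 is therefore 0%, most likely between 0% and 15%, because compound 2 gave 0% and compound 3 gave 0%.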

Compound 4, a percentage reported as activity, at one dose (the size of the read-out at that dose, not a potency): 0%
Compound 4: middle estimate and measured number agree at the digits printed; the range from low to high includes it.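

Putting chloro in place of methyl on the aromatic ring gives no change at the digits printed from compound 3 to compound 4 (within the scatter) in this assay, and this agrees with the same change on the other core: the same change on two cores in this assay, no change at the digits printed (within the scatter) from compound 1 to compound 2 and no change at the digits printed (within the scatter) from compound 3 to compound 4, 0 percentage points apart, within the scatter of two such steps

Putting hydrogen in place of methyl on the saturated chain carbon gives no change at the digits printed from compound 2 to compound 4 (within the scatter), which also agrees with the earlier step: the same change on two cores in this assay, no change at the digits printed (within the scatter) from compound 1 to compound 3 and no change at the digits printed (within the scatter) from compound 2 to compound 4, 0 percentage points apart, within the scatter of two such steps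

Within the data shown here, compound 4, like the other three compounds, stands at 0%, so these matches show only that neither change brought out a measurable effect on these cores at this dose, not that either change would be equally silent on a compound with real activity.

The compounds shown leave open whether a methoxy group at the same place on the aromatic ring, or a longer chain on the saturated carbon, would give any reading above zero in this assay. They also leave open how the chloro and methyl groups compare on a core that is active in this test.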